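The compounds below may be only part of what the source reports. "The series", "measured", "known", "first", "only" and "open" are said of these compounds alone.

Measured compounds:
Compound 1, `Cc1cccnc1-c1ccc(C(=O)Nc2ccc(F)cc2)cc1`: in a functional assay for antagonist activity at transient receptor potential cation channel subfamily V member 1 (Rattus norvegicus) (a lower number here means a stronger inhibitor, a higher number a weaker inhibitor), compound 1 gives > 4000 nM, which is a limit of the assay and not a number.
Compound 2, `CC(C)(C)c1ccc(NC(=O)c2ccc(-c3ncccc3F)cc2)cc1`: in this assay compound 2 gives 1 nM.

Going by the values given here, compound 2 therefore holds the only numerical value in this set; the other entry sits at the limit of > 4000 nM in this assay, at which 1 of the 2 values shown sits. Compound 3, `CC(C)(C)c1ccc(NC(=O)c2ccc(-c3ncccc3N(S(C)(=O)=O)S(C)(=O)=O)cc2)cc1`, has not yet been measured in this assay. It differs from compound 2 in a single place: bis(methylsulfonyl)amino in place of fluoro on an aromatic carbon. Among the compounds with values here, no measured step of this kind exists, so the size of the change remains open. The working expectation is a loss of potency beyond the usual scatter, the step being estimated at a 100-fold higher number from compound 2 to compound 3 (2.00 log units; beyond the scatter). Compound 3 is accordingly expected at 100 nM in this assay, within a wide range from 5 nM to 3000 nM.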

Compound 3, half-maximal inhibitory concentration: 0.4 nM
Compound 3: the middle estimate sits 250-fold (2.40 log units) above what was measured, outside the stated range (below it).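

Going by these compounds alone, at this position, on an aromatic carbon two atoms from the ring nitrogen and ortho to a large group, the single fluorine of compound 2 can be replaced by the far larger bis(methylsulfonyl)amino without loss of potency: in this assay the change gives a 2.5-fold lower number from compound 2 to compound 3 (0.40 log units; beyond the scatter). The step is modest but beyond the usual scatter, so within this pair potency does not require a small substituent here. Nothing in the data shown accounts for the step.

Within the data shown here, with only one step at this position, the result cannot be assigned to the size of the new group or to its hydrogen-bond acceptors. Going by these compounds, the effect at this carbon of a simple amine, a carboxylic acid or a single methylsulfonylamino group remains open.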